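The source may report more compounds than this note shows. Statements on the series, on what has been measured and on what is new or still open speak of the compounds shown alone.

Compound 1 `COC(=O)c1cn(CC=C(C)C)nn1` and compound 2 `COC(=O)c1cn(C/C=C(\C)CCC=C(C)C)nn1` share one core. In a physicochemical assay for lipophilicity, measured as octanol-water partition (a higher number here means a more lipophilic compound, a lower number a more polar compound), compound 1 gives 1.3, and compound 2 gives 3.2. The change between them is 3-methylbut-2-en-1-yl in place of hydrogen on a saturated chain carbon bound to a double-bonded chain carbon, and it produced a number 1.90 log units higher from compound 1 to compound 2 (beyond the scatter). Compound 3 `CCCCCCCCc1cn(CC=C(C)C)nn1` rests on a different core; the difference between the two cores is not broken down here. In this assay compound 3 gives 4.92, the highest of the three measured numbers. Compound 4 `CCCCCCCCc1cn(C/C=C(\C)CCC=C(C)C)nn1` carries the same change relative to compound 3, namely (3-methylbut-2-en-1-yl in place of hydrogen on a saturated chain carbon bound to a double-bonded chain carbon). A step of similar size is expected, a number 1.78 log units higher from compound 3 to compound 4 (beyond the scatter), because the same change earlier gave a number 1.90 log units higher from compound 1 to compound 2 (beyond the scatter). Compound 4 is accordingly estimated at 6.7, with a range from 6 to 7.4. What compound 4 actually shows in this assay is the next question.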

Compound 4, partition coefficient: 6.92
For compound 4 the middle estimate is 0.22 log units below the measured one, within the range that was stated.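

In this assay the 3-methylbut-2-en-1-yl change gives a number 2.00 log units higher from compound 3 to compound 4 (beyond the scatter), and on the other core it gave a number 1.90 log units higher from compound 1 to compound 2 (beyond the scatter), so both steps run the same way and both lie beyond the scatter. This shows the change carrying over between these two cores, but one pair of cores does not establish a rule for the whole series. Nothing shown here explains the size of either step.

The compounds shown leave open whether the step holds on a core carrying an amine or a carboxylic acid. They also leave open what a longer chain would do on a saturated chain carbon bound to a double-bonded chain carbon.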